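The source may report more compounds than this note shows. Statements on the series, on what has been measured and on what is new or still open speak of the compounds shown alone.

Compound 1 `Cc1nc(N)c2nc(-c3ccccc3)sc2n1` gives 34 nM in an assay on CHO cells for displacement of a labelled ligand from adenosine receptor A1 (Homo sapiens), read by scintillation counting, with a stated time of 3 h; on this read-out higher numbers stand for weaker inhibition and lower numbers for stronger inhibition.
Compound 2 `Nc1nc(-c2cccc(CO)c2)nc2sc(-c3ccccc3)nc12` gives 32 nM in this assay.
Compound 3 `COc1ccc(-c2nc(N)c3nc(-c4ccccc4)sc3n2)cc1` gives 225 nM in this assay.

Compound 2 shows the lowest of the three numbers, though compound 1 sits within the scatter of it and only compound 3 stands apart. Compound 4 `N#Cc1cccc(-c2nc(N)c3nc(-c4ccccc4)sc3n2)c1` differs from compound 2 by cyano in place of hydroxymethyl on an aromatic carbon. Within the data shown here, no measured step replaces the hydroxymethyl alone. The step of a 1.1-fold lower number from compound 1 to compound 2 (0.03 log units; within the scatter) shows that the whole 3-(hydroxymethyl)phenyl adds nothing beyond the scatter over methyl, while a 7.0-fold higher number from compound 2 to compound 3 (0.85 log units; beyond the scatter) shows a modest loss when a 4-methoxyphenyl takes its place. Compound 4 is therefore expected to stay near compound 2, with no step beyond the scatter, a 1.3-fold higher number from compound 2 to compound 4 (0.10 log units; within the scatter). Compound 4 is estimated at 40 nM, between 15 nM and 120 nM.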

Compound 4, inhibition constant: 594 nM
Compound 4: the middle estimate sits 15-fold (1.17 log units) below what was measured; the measured number lies above the stated range.
By their numbers in this assay, from the lowest: compounds 2 and 1 (each within the scatter of the next); then compound 3; then compound 4.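

Changing only the group on the six-membered aromatic ring gives a large step in this assay, a 19-fold higher number from compound 2 to compound 4 (1.27 log units; beyond the scatter), so the number depends on that group and not merely on the ring being present. The 3-cyanophenyl also compares poorly with the other two groups at this carbon, a 17-fold higher number from compound 1 to compound 4 (1.24 log units; beyond the scatter) and a 2.6-fold higher number from compound 3 to compound 4 (0.42 log units; beyond the scatter). Nothing available explains these steps.

The compounds shown leave open whether the step follows from losing hydroxymethyl or from introducing cyano, and how an aminomethyl group, a carboxylic acid or a hydroxyethyl chain would read at this place.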